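A few compounds are considered here, and "the series" means these few. Any claim that something is new, unique, unknown or untested is made for them only; others in the source may bear on it.

Working notes on the series, cytotoxicity read as an ADME assay on MRC5 cells (Homo sapiens) for cytotoxicity, read by MTT assay, with a stated time of 4 h; a higher number here means that more compound is needed for the effect, a lower number that less compound is needed.

Compound 1 `CC(C)(C)c1ccc(CC(CN)(Cc2ccc(C(C)(C)C)cc2)C(=O)NCCCN)cc1` gives 35000 nM in this assay. Compound 3 `CC(C)(C)c1ccc(CC(CN)(Cc2ccc(C(C)(C)C)cc2)C(=O)N[C@@H](CCCNC(=N)N)C(N)=O)cc1` is compound 1 with one change, (a group of 11 heavy atoms (6 carbon, 4 nitrogen, 1 oxygen; no ring) in place of a group of 4 heavy atoms (3 carbon, 1 nitrogen; no ring), on an amide-type nitrogen), and in this assay compound 3 gives 158000 nM; the step of a 4.5-fold higher number from compound 1 to compound 3 (0.65 log units; beyond the scatter) is the only measured instance of this change among the compounds shown. Compound 2 `NCCCNC(=O)C(CN)(Cc1ccc(C(F)(F)F)cc1)Cc1ccc(C(F)(F)F)cc1` rests on a different core; the difference between the two cores is not broken down here. In this assay compound 2 gives 30000 nM, which lies within the scatter of compound 1, so the two cores are not separated by this read-out.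

Compound 4 `N=C(N)NCCC[C@H](NC(=O)C(CN)(Cc1ccc(C(F)(F)F)cc1)Cc1ccc(C(F)(F)F)cc1)C(N)=O` carries the same change on the core of compound 2: a group of 11 heavy atoms (6 carbon, 4 nitrogen, 1 oxygen; no ring) in place of a group of 4 heavy atoms (3 carbon, 1 nitrogen; no ring), on an amide-type nitrogen. This change occurs twice among the compounds shown, once measured. Going by the values given here, for compound 4 the expected step is a 4.3-fold higher number from compound 2 to compound 4 (0.64 log units; beyond the scatter), because a 4.5-fold higher number from compound 1 to compound 3 (0.65 log units; beyond the scatter) is the only measured instance of this change and compound 2 starts from a value within the scatter of compound 1. In this assay compound 4 is expected at 130000 nM, with a likely range from 60000 nM to 280000 nM.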

Compound 4, half-maximal effective concentration: > 634000 nM
Compound 4: no number, only a limit; the forecaster's own chance of this, stated with the estimate: 15%; middle value at least 4.8-fold (0.68 log units) from the limit.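

Compound 4 gives > 634000 nM in this assay, which is a limit of the assay and not a number: the limit of > 634000 nM in this assay, at which 1 of the 4 values shown sits.

The change therefore gives an at least 21-fold higher number from compound 2 to compound 4 (1.32 log units; beyond the scatter), and the two cores do not share one size of step: the same change on two cores in this assay, a 4.5-fold higher number (0.65 log units; beyond the scatter) from compound 1 to compound 3 and an at least 21-fold higher number (1.32 log units; beyond the scatter) from compound 2 to compound 4, at least 4.6-fold (0.67 log units) apart, beyond the scatter of two such steps

The direction is the same on both cores, with a higher number once the 3-aminopropyl group is replaced, but this rests on a single pair per core, the full size of the step on the core of compound 2 remains unread, and no size can be carried with confidence to a further core.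

Open, as far as these compounds go, is whether a longer amine chain or a carboxylic acid on the amide-type nitrogen would give a step of similar size on the two cores. Also open, from the compounds shown here alone, is how the same change would read on a core with a chlorine atom or a methoxy group in place of the groups on the aromatic rings of compound 1 and compound 2.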